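A trichlorophenyl variant in a weakly active series

The compounds below may be only part of what the source reports. "The series", "measured", "known", "first", "only" and "open" are said of these compounds alone.

Compound 3 `Cc1ccc(C)c(-n2nncc2CN2C(=O)C3(C(C#N)=C(N)Oc4c(N)cc5nc6ccccc6nc5c43)c3ccccc32)c1` is one of three measured members built on a shared core. In a functional assay on A549 cells (Homo sapiens) for antiproliferative activity, read by MTT assay, with a stated time of 48 h (a higher number here means a weaker inhibitor, a lower number a stronger inhibitor), compound 3 gives only a limit of the assay, > 50000 nM. Compound 2 `CC(=O)Nc1ccc(-n2nncc2CN2C(=O)C3(C(C#N)=C(N)Oc4c(N)cc5nc6ccccc6nc5c43)c3ccccc32)cc1` likewise gives only a limit in this assay, > 50000 nM. Compound 1 `N#CC1=C(N)Oc2c(N)cc3nc4ccccc4nc3c2C12C(=O)N(Cc1cnnn1-c1ccccc1Cl)c1ccccc12` gives 29800 nM in this assay. Two of the three values thus sit at the limit of > 50000 nM in this assay, at which 2 of the 3 values shown sit. The step of an at least 1.6-fold higher number from compound 1 to compound 3 (0.22 log units; that floor lies within the scatter) and the step of an at least 1.6-fold higher number from compound 1 to compound 2 (0.22 log units; that floor lies within the scatter) have floors within the scatter, and the step that the two limits leave unreadable from compound 2 to compound 3 cannot be read from two limits. Compound 3 therefore stands at the limit, without a number of its own.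

Compound 4 `N#CC1=C(N)Oc2c(N)cc3nc4ccccc4nc3c2C12C(=O)N(Cc1cnnn1-c1c(Cl)cc(Cl)cc1Cl)c1ccccc12` differs from compound 3 by 2,4,6-trichlorophenyl in place of 2,5-dimethylphenyl on an aromatic nitrogen. Among the compounds with values here, the only step touching the same place is an at least 1.6-fold higher number from compound 1 to compound 3 (0.22 log units; that floor lies within the scatter), and compound 2 ends at the same limit. Within the data shown here, no step read beyond the scatter bears on this change, so no shift beyond the scatter is expected in either direction, and the chance remains that compound 4 also returns only a limit. Compound 4 is expected to give about 45000 nM in this assay, between 20000 nM and 100000 nM. The step of an at least 1.1-fold lower number from compound 3 to compound 4 (0.04 log units; that floor lies within the scatter) is accordingly estimated to lie within the scatter.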

Compound 4, half-maximal inhibitory concentration: > 50000 nM
Compound 4 was reported as a limit (the forecaster's own chance of this, stated with the estimate: 60%); middle value at least 1.1-fold (0.04 log units) away from the limit.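

With 2,4,6-trichlorophenyl on the aromatic nitrogen, compound 4 also gives only a limit in this assay, > 50000 nM, so a ring carrying chlorine on several positions yields no number here. Replacing the 2-chlorophenyl of compound 1 with this group gives an at least 1.6-fold higher number from compound 1 to compound 4 (0.22 log units; that floor lies within the scatter), so the data do not establish a real loss of activity. The steps to compound 4 from compound 2 and compound 3 cannot be read, and this position now has a third group without a number of its own: the limit of > 50000 nM in this assay, at which 3 of the 4 values shown sit.

Going by these compounds, the actual values of compound 2, compound 3 and compound 4 remain open, so these three cannot be ordered. Also open, on these data alone, is what a plain phenyl ring, or a phenyl ring carrying an amine or a carboxylic acid, would give at this position in this assay.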